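Adding a Second Trifluoromethyl to a Sulfonamide Anilide

This account rests on a few compounds, and the source may have more. Where it says the series, first, only, none or still open, it means among the compounds named here.

Measured so far:
Compound 1 `CS(=O)(=O)Nc1ccc(NC(=O)c2cccc(C(F)(F)F)c2)cc1F`. In an ADME assay on HEK293 cells (Homo sapiens) for cytotoxicity, read by MTT assay, with a stated time of 48 h (on this read-out lower numbers stand for stronger inhibition and higher numbers for weaker inhibition), compound 1 gives > 250000 nM, which is a limit of the assay rather than a number.
Compound 2 `CS(=O)(=O)Nc1ccc(NC(=O)c2cc(C(F)(F)F)cc(C(F)(F)F)c2)cc1F`. In this assay compound 2 gives > 250000 nM, also a limit.
Compound 3 `O=C(Nc1ccc(NS(=O)(=O)C(F)(F)F)c(F)c1)c1cccc(C(F)(F)F)c1`. In this assay, going by the values given here, compound 3 gives 152000 nM, the only number among the three.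

Compound 2 differs from compound 1 by trifluoromethyl in place of hydrogen on an aromatic carbon. This gives a step that the two limits leave unreadable from compound 1 to compound 2, because both values sit at the limit of > 250000 nM in this assay, at which 2 of the 3 values shown sit. Compound 3 differs from compound 1 by trifluoromethyl in place of methyl on a sulfonyl sulfur, and that change gives an at least 1.6-fold lower number from compound 1 to compound 3 (0.21 log units; that floor lies within the scatter).

Compound 4 `O=C(Nc1ccc(NS(=O)(=O)C(F)(F)F)c(F)c1)c1cc(C(F)(F)F)cc(C(F)(F)F)c1` has not yet been measured. It differs from compound 3 by trifluoromethyl in place of hydrogen on an aromatic carbon, the same change that turns compound 1 into compound 2, here made on the core of compound 3. The earlier step of this kind has no readable size, so the expectation for compound 4 rests on compound 3 alone, anchored at 152000 nM. Compound 4 is expected to give 150000 nM, between 60000 nM and 250000 nM. That estimate means an expected step of a 1.0-fold lower number from compound 3 to compound 4 (0.01 log units; within the scatter).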

Compound 4, half-maximal inhibitory concentration: 164000 nM
Beside the measured number, compound 4's estimate is 1.1-fold (0.04 log units) below it; measured number inside the range.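

In this assay, a second trifluoromethyl on the aromatic ring gives a 1.1-fold higher number from compound 3 to compound 4 (0.03 log units; within the scatter), while the same change on the core of compound 1 is a step that cannot be read, as both of its ends are limits: the limit of > 250000 nM in this assay, at which 2 of the 4 values shown sit. Replacing methyl with trifluoromethyl on the sulfonyl sulfur has now been seen on two cores, and on the newer one it gives an at least 1.5-fold lower number from compound 2 to compound 4 (0.18 log units; that floor lies within the scatter), which can be set beside the earlier step: the same change on two cores in this assay, an at least 1.6-fold lower number (0.21 log units; that floor lies within the scatter) from compound 1 to compound 3 and an at least 1.5-fold lower number (0.18 log units; that floor lies within the scatter) from compound 2 to compound 4; the limit leaves it open whether they differ These two floors show neither a real shift on either core nor that the change has the same size on both, so they do not establish that its effect carries from one core to the other.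

The compounds shown leave open whether another group on the aromatic ring, such as a nitrile or an amine, or a longer chain on the sulfonyl sulfur would move the number beyond the scatter. Also open, as far as these compounds go, is where compound 1 and compound 2 would read past their limits, and with that the true size of every step that touches them.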